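The compounds below may be only part of what the source reports. "The series", "measured", "known", "first", "only" and "open" are said of these compounds alone.

Series notes. In an assay on isolated protein for inhibition of proto-oncogene tyrosine-protein kinase receptor Ret variant V804M (Homo sapiens), read by radiometric assay and 33P incorporation, in the presence of a further agent that is not named here (on this read-out higher numbers stand for weaker inhibition and lower numbers for stronger inhibition), compound 1 `CC(C)n1nc(-c2ccon2)c2c(N)ncnc21` gives 903 nM, the second highest of the three numbers in hand. Compound 2 `CC(C)n1nc(-c2cc(C(C)(C)C)on2)c2c(N)ncnc21` gives 2100 nM in this assay, and compound 3 `CC(C)(O)Cn1nc(-c2cc(C3CC3)on2)c2c(N)ncnc21` gives 217 nM. Going by the values given here, the only single-point step in hand, a 2.3-fold higher number from compound 1 to compound 2 (0.37 log units; beyond the scatter), is modest and concerns a substituent on the five-membered ring that is itself removed in the step now of interest. Among the compounds with values here, compound 3 differs from compound 1 in two places at once, so its value says only that lower numbers are reachable. Compound 4 `CC(C)n1nc(/C=N/O)c2c(N)ncnc21` carries a group of 3 heavy atoms (1 carbon, 1 nitrogen, 1 oxygen; no ring) in place of a group of 5 heavy atoms (3 carbon, 1 nitrogen, 1 oxygen; one five-membered aromatic ring with 2 hetero atoms), on an aromatic carbon. Within the data shown here, no measured step bears directly on the loss of the aromatic ring; the expectation rests on the one change at that end of the molecule, a 2.3-fold higher number from compound 1 to compound 2 (0.37 log units; beyond the scatter), which moved this assay only modestly, with added uncertainty for a larger change. The step to compound 4 is therefore expected to be a 2.8-fold higher number from compound 1 to compound 4 (0.44 log units; beyond the scatter), towards a higher number. Compound 4 is estimated at 2500 nM, with a range from 600 nM to 10000 nM.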

Compound 4, half-maximal inhibitory concentration: 3680 nM
Compound 4: middle estimate off by 1.5-fold (0.17 log units), on the low side; measured number inside the range.
By their numbers in this assay, from the lowest: compound 3; then compound 1; then compounds 2 and 4 (each within the scatter of the next).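

Series notes, continued. In this assay, exchanging the 1,2-oxazol-3-yl for the ring-free group gives a 4.1-fold higher number from compound 1 to compound 4 (0.61 log units; beyond the scatter) and shows that an aromatic ring on this aromatic carbon can be given up at a modest cost, with inhibition still measurable. The change removes the ring and adds a hydrogen-bond donor in one step, and this pair of compounds cannot separate the two. No measurement in hand accounts for the shift.

As far as these compounds go, whether a nitrile or a primary amide on this carbon would give a number closer to that of compound 1 remains open. Also open, from the compounds shown here alone, is whether the group that stands in place of isopropyl in compound 3 would lower the number when paired with the ring-free group of compound 4.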